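The compounds below may be only part of what the source reports. "The series", "measured", "known", "first", "only" and "open" are said of these compounds alone.

Compound 3, `NCC(=O)N1CCC[C@@H]1C(=O)Nc1nc2ccc(OC(F)(F)F)cc2s1`, is the only one of the three measured compounds to give an actual number in a physicochemical assay for pharmacokinetics, at pH 7.4 (a higher number here means that the compound lasts longer, a lower number that the compound disappears faster), at 0.2 h. Compound 1, `CNCC(=O)N(C)CC(=O)Nc1nc2ccc(OC(F)(F)F)cc2s1`, reaches only a limit of the assay, < 0.1 h. Compound 2, `CCNCC(=O)N(C)CC(=O)Nc1nc2ccc(OC(F)(F)F)cc2s1`, likewise gives a limit, < 0.25 h. Compound 4, `CC(C)(C)NCC(=O)N1CCC[C@@H]1C(=O)Nc1nc2ccc(OC(F)(F)F)cc2s1`, differs from compound 3 by tert-butyl in place of hydrogen on an amine nitrogen. Among the measured compounds shown here, the one measured step that resembles this change, a step that the two limits leave unreadable from compound 1 to compound 2, cannot be sized, so the measurements give no firm guide to either direction or size. Compound 4 is therefore estimated only loosely, at 2 h, within a range from 0.3 h to 15 h. That estimate means a step of a 10-fold higher number from compound 3 to compound 4 (1.00 log units; beyond the scatter), expected to exceed the scatter but held with little confidence.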

Compound 4, half-life: > 24 h
Compound 4: a limit, no number; the forecaster's own chance of this, stated with the estimate: 10%; at least 12-fold (1.07 log units) between middle value and limit.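

In this assay, the amine nitrogen proves to be a position where one change has a large effect: tert-butyl in place of hydrogen brings an at least 120-fold higher number from compound 3 to compound 4 (2.07 log units; beyond the scatter). The earlier step from compound 1 to compound 2 cannot be read, so this is the first readable step among these compounds. Compound 4 gives > 24 h, which is a limit of the assay, not a number.

Going by these compounds, it remains open whether an isopropyl or a cyclopropyl group on this nitrogen would give a similar step. Also open, on these data alone, is whether tert-butyl would act alike on the core of compound 1.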